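A few compounds are considered here, and "the series" means these few. Any claim that something is new, unique, unknown or untested is made for them only; others in the source may bear on it.

Working notes on the series. The shared core is shown by compound 1 `CCS(=O)(=O)N(Cc1cccnc1)c1ccc(C(O)c2ccccc2)cc1`; the compounds differ only in the group on the saturated chain carbon bound to two aromatic carbons. In an assay on isolated protein with metabotropic glutamate receptor 2 (Homo sapiens) as the target (a higher number here means that more compound is needed for the effect, a lower number that less compound is needed), compound 1 gives > 30000 nM, which is a limit of the assay rather than a number (the limit of > 30000 nM in this assay, at which 1 of the 3 values shown sits). Compound 2 `C=C(c1ccccc1)c1ccc(N(Cc2cccnc2)S(=O)(=O)CC)cc1` gives 780 nM in this assay. Compound 3 `CCS(=O)(=O)N(Cc1cccnc1)c1ccc(C(C)c2ccccc2)cc1` gives 1400 nM in this assay; against compound 2 the gap is a 1.8-fold higher number from compound 2 to compound 3 (0.25 log units; within the scatter). The steps from the limit are large: an at least 21-fold lower number from compound 1 to compound 3 (1.33 log units; beyond the scatter) and an at least 38-fold lower number from compound 1 to compound 2 (1.58 log units; beyond the scatter).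

Compound 4 `CCS(=O)(=O)N(Cc1cccnc1)c1ccc(Cc2ccccc2)cc1` is not yet measured in this assay; it differs from compound 3 by hydrogen in place of methyl on a saturated chain carbon bound to two aromatic carbons. For the measured compounds named here, no measured step removes a methyl from that carbon. Going by the values given here, the steps that bear on the same carbon are an at least 21-fold lower number from compound 1 to compound 3 (1.33 log units; beyond the scatter), large, and a 1.8-fold higher number from compound 2 to compound 3 (0.25 log units; within the scatter), within the scatter; the large change came with replacing hydroxy, whereas methyl against the ethenyl carbon made no difference beyond the scatter. No step beyond the scatter is therefore expected in this assay. For compound 4 the expected step is a 1.1-fold higher number from compound 3 to compound 4 (0.03 log units; within the scatter). The estimate for compound 4 is 1500 nM, expected between 500 nM and 5000 nM.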

Compound 4, half-maximal effective concentration: 1600 nM
For compound 4 the middle estimate is 1.1-fold (0.03 log units) below the measured one, within the range that was stated.
By their numbers in this assay, from the lowest: compounds 2, 3 and 4 (each within the scatter of the next, the first and the last beyond it). At a limit, above all of these: compound 1.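

On the saturated chain carbon bound to two aromatic carbons, hydrogen and methyl read alike in this assay (a 1.1-fold higher number from compound 3 to compound 4 (0.06 log units; within the scatter)), so the methyl adds nothing beyond the scatter, while the large step stays with hydroxy: compound 4, with hydrogen there, again stands far from the hydroxy compound (an at least 18-fold lower number from compound 1 to compound 4 (1.27 log units; beyond the scatter)). For the compounds shown here, the plain benzyl also gives the first step beyond the scatter against the 1-phenylethenyl group, though only a modest one (a 2.1-fold higher number from compound 2 to compound 4 (0.31 log units; beyond the scatter)), and compound 3 lies within the scatter of both compound 2 and compound 4. Compound 1 stands at a limit of the assay, not at a number: the limit of > 30000 nM in this assay, at which 1 of the 4 values shown sits.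

Open, as far as these compounds go, is how an amine, a methoxy group or fluorine on that same carbon would read in this assay. Also open, from the compounds shown here alone, is whether a longer chain there, such as ethyl, would stay level with methyl and hydrogen.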